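From compound 3 to compound 4: a sec-butyl addition

This account rests on a few compounds, and the source may have more. Where it says the series, first, only, none or still open, it means among the compounds named here.

Measured in a physicochemical assay for metabolic stability, in phosphate buffer, at pH 7.4; on this read-out higher numbers stand for a longer-lived compound and lower numbers for a shorter-lived compound:
compound 1 `Cc1nc(C)c(C(=O)Oc2ccc(-c3cc(=O)c4c(O)c(O)c(O)cc4o3)cc2)nc1C`: 15.1 h
compound 2 `Cc1nc(C)c(COC(=O)COc2ccc(-c3cc(=O)c4c(O)c(O)c(O)cc4o3)cc2)nc1C`: 21.4 h
compound 3 `Cc1nc(C)c(COC(=O)NCC(=O)Oc2ccc(-c3cc(=O)c4c(O)c(O)c(O)cc4o3)cc2)nc1C`: 14.3 h

Compound 3, at 14.3 h, lies within the usual scatter of both other compounds, the spread expected when a measurement is simply repeated. Compound 4 `CC[C@H](C)[C@@H](NC(=O)OCc1nc(C)c(C)nc1C)C(=O)Oc1ccc(-c2cc(=O)c3c(O)c(O)c(O)cc3o2)cc1` carries sec-butyl in place of hydrogen on a saturated chain carbon bound to an amide-type nitrogen and a carbonyl carbon. For the measured compounds named here, no two measured compounds differ in only one place, so no single change can be read directly. Their chains differ, yet compound 2 at 21.4 h stays within the scatter of compound 3 at 14.3 h. The estimated step of a 1.3-fold higher number from compound 3 to compound 4 (0.10 log units; within the scatter) is therefore expected to stay within the scatter in this assay. The expected value for compound 4 is 18 h, within an estimated range from 10 h to 35 h.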

Compound 4, half-life: 64.8 h
The estimate for compound 4 lay 3.6-fold (0.56 log units) below the measured number; measured number above the stated range.
By their numbers in this assay, from the lowest: compounds 3, 1 and 2 (each within the scatter of the next); then compound 4.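

In this assay, sec-butyl in place of hydrogen on a saturated chain carbon bound to an amide-type nitrogen and a carbonyl carbon gives a 4.5-fold higher number from compound 3 to compound 4 (0.66 log units; beyond the scatter). For the compounds shown here, this is the first single change here that can be read directly, and it lies beyond the scatter, so what sits at this position can shift the half-life. Nothing available explains the rise. The compounds shown leave open whether methyl, phenyl or a carboxylic acid on this carbon would do the same, and whether the defined stereocentre of sec-butyl plays any part.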